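Thiourea aryl swap: from dichlorophenyl to methoxyphenyl

A few compounds are considered here, and "the series" means these few. Any claim that something is new, unique, unknown or untested is made for them only; others in the source may bear on it.

Three diaryl thioureas sharing one core have been examined in a functional assay on HCT-116 cells (Homo sapiens) for antiproliferative activity, read by MTT assay; on this read-out lower numbers stand for stronger inhibition and higher numbers for weaker inhibition. Compound 1 `CNC(=O)c1ccc(Oc2cccc(NC(=S)Nc3cc(C(F)(F)F)cc(C(F)(F)F)c3)c2)nc1` gives 2500 nM, compound 2 `CNC(=O)c1ccc(Oc2cccc(NC(=S)Nc3ccc(F)c(C(F)(F)F)c3)c2)nc1` gives 19000 nM, and compound 3 `CNC(=O)c1ccc(Oc2cccc(NC(=S)Nc3ccc(Cl)cc3Cl)c2)nc1` gives 20900 nM. Compound 3 therefore stands at the highest number of the three, though its gap to compound 2 lies within the scatter, while compound 1 sits well beyond it. Compound 4 `CNC(=O)c1ccc(Oc2cccc(NC(=S)Nc3ccc(OC)cc3)c2)nc1` carries the change (4-methoxyphenyl in place of 2,4-dichlorophenyl on an amide-type nitrogen). Within the data shown here, no measured pair shows this exact swap. Given that compound 3 already sits at 20900 nM, compound 4 is expected to stay close, with a step of a 1.2-fold higher number from compound 3 to compound 4 (0.08 log units; within the scatter) that is not beyond the scatter. Compound 4 is thus estimated at 25000 nM, within a range from 8000 nM to 70000 nM.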

Compound 4, half-maximal inhibitory concentration: 49800 nM
Compound 4: middle estimate off by 2.0-fold (0.30 log units), on the low side; the range from low to high includes it.
By their numbers in this assay, from the lowest: compound 1; then compounds 2 and 3 (each within the scatter of the next); then compound 4.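

In this assay, putting 4-methoxyphenyl in place of 2,4-dichlorophenyl on the amide-type nitrogen gives a 2.4-fold higher number from compound 3 to compound 4 (0.38 log units; beyond the scatter), a modest step. It shows that the aryl group at this position can still move the number upward, even from the already high value of compound 3. Nothing measured here accounts for this shift.

Going by these compounds, whether a 4-chlorophenyl or a plain phenyl group would sit nearer compound 3 or compound 4 remains open. So does the question of how a 4-aminophenyl group would read at this position.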